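A few compounds are considered here, and "the series" means these few. Any claim that something is new, unique, unknown or untested is made for them only; others in the source may bear on it.

Compounds measured so far:
compound 1, `CCc1nn2c(C(C)c3ccc(CC(C)C)cc3)nnc2s1` — 44%
compound 2, `CC(C)Cc1ccc(C(C)c2nnc3sc(-c4ccc(Br)cc4)nn23)cc1` — 68%

In a functional assay on the whole organism (strain Wistar albino) for inhibition, with Rattus norvegicus as the target, read by paw edema, with stated times of 30 min and 2.5 h, at a dose of 20 mg/kg by the oral route (a lower number here means less inhibition, a higher number more inhibition at the dose given (going by the name of the read-out)), compound 2 gives 68%, the highest of the two numbers recorded. Its nearest neighbour is compound 1, which gives 44%. Among the measured compounds shown here, the only measured step, a number 24 percentage points higher from compound 1 to compound 2 (beyond the scatter), came with 4-bromophenyl in place of ethyl on an aromatic carbon of the shared core.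

Compound 3, `CC(C)Cc1ccc(C(C)c2nnc3sc(-c4ccccc4Cl)nn23)cc1`, carries 2-chlorophenyl in place of 4-bromophenyl on an aromatic carbon. For the measured compounds named here, no measured step exchanges one substituted phenyl for another, so the step from compound 1 to compound 2 bears on this change only loosely: it shows that an aryl group at this position accompanies a higher number than ethyl, but says nothing about how the halogen and its position on the ring matter. The new group keeps the same count of heavy atoms and the same single aromatic ring, so a step within the scatter, or at most a small one, seems the more likely outcome.

Compound 3 is therefore expected to give about 60%, with a range from 44% to 76%. The expected step is a number 8 percentage points lower from compound 2 to compound 3 (within the scatter).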

Compound 3, a percentage reported as inhibition, in the whole organism at one dose (the size of the read-out at that dose, not a potency): 58%
For compound 3 the middle estimate is 2 percentage points above the measured one, and the stated range covers the measured number.
By their numbers in this assay, from the lowest: compound 1; then compounds 3 and 2 (each within the scatter of the next).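

In this assay, 2-chlorophenyl in place of 4-bromophenyl gives a number 10 percentage points lower from compound 2 to compound 3 (within the scatter) and so does not separate these two aryl groups, although the halogen and its place on the ring both differ between them. Set against ethyl on the same aromatic carbon of the shared core, 2-chlorophenyl gives a number 14 percentage points higher from compound 1 to compound 3 (beyond the scatter) and so the link between an aryl group and a number beyond the scatter above that of ethyl now rests on two aryl groups rather than one, with neither of the two going against it. No independent measurement among these data bears on what lies behind either step.

Because the halogen and its place on the ring change together between compound 2 and compound 3, the part played by each remains unresolved, and these are readings at a single dose rather than measures of potency. Also open, going by these compounds, is how an unsubstituted phenyl, a 4-chlorophenyl, a phenyl ring carrying an amine or a carboxylic acid, or a longer alkyl chain such as hexyl would read at this position.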